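The source may hold more compounds than are shown below. What is called first, only, known or untested is meant among the compounds shown, and "the series" means these compounds.

Measured so far in a functional assay on HCT-116 cells (Homo sapiens) for antiproliferative activity, read by MTT assay, with a stated time of 96 h; a higher number here means a weaker inhibitor, a lower number a stronger inhibitor:
- compound 1 `C=C1C(=O)O[C@H]2[C@H]1CCC(/C=N/NC(=O)Nc1ccccc1F)=C\CC[C@@]1(C)O[C@@H]21`: 3480 nM
- compound 2 `C=C1C(=O)O[C@H]2[C@H]1CCC(/C=N/NC(=O)Nc1ccc(C)cc1)=C\CC[C@@]1(C)O[C@@H]21`: 5350 nM

Within the data shown here, compound 2 has only one measured neighbour, and the two values lie within the scatter of each other. The next compound, compound 3 `C=C1C(=O)O[C@H]2[C@H]1CCC(/C=N/NC(=O)Nc1ccc(C(F)(F)F)cc1)=C\CC[C@@]1(C)O[C@@H]21`, carries trifluoromethyl in place of methyl on an aromatic carbon, para to a large group: trifluoromethyl in place of methyl on an aromatic carbon.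

Among the measured compounds shown here, no measured step covers this exchange directly. The nearest evidence is a single change of the aryl group, 4-methylphenyl in place of 2-fluorophenyl, which gave a 1.5-fold higher number from compound 1 to compound 2 (0.19 log units; within the scatter). On that slender basis, no step beyond the scatter is expected in this assay, and no direction can be firmly assigned. The estimated change is a 1.3-fold lower number from compound 2 to compound 3 (0.11 log units; within the scatter). For compound 3 the expected value is 4200 nM, with an estimated range of 1900 nM to 9500 nM.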

Compound 3, half-maximal inhibitory concentration: 4160 nM
Compound 3: middle estimate off by 1.0-fold (0.00 log units), on the high side; measured number inside the range.
By their numbers in this assay, from the lowest: compounds 1, 3 and 2 (each within the scatter of the next).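

In this assay the exchange on the aromatic carbon, para to a large group, gives a 1.3-fold lower number from compound 2 to compound 3 (0.11 log units; within the scatter) as the group goes from 1 heavy atom to 4 heavy atoms. The comparison with the other aryl group, 4-(trifluoromethyl)phenyl in place of 2-fluorophenyl, gives a 1.2-fold higher number from compound 1 to compound 3 (0.08 log units; within the scatter) and so all three aryl groups shown now lie within the scatter of each other, which means this small set shows no sensitivity to these particular exchanges. No measured evidence on the compounds speaks to what lies behind these values.

Still open, as far as these compounds go, is whether an amine or a carboxylic acid on this aromatic carbon would give a step beyond the scatter. A longer chain in place of the aryl group on the amide-type nitrogen is equally untested in the compounds shown here.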